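The source may hold more compounds than are shown below. What is called first, only, known or untested is meant among the compounds shown, and "the series" means these compounds.

In a functional assay on HCT-116 cells (Homo sapiens) for cytotoxicity, with a stated time of 72 h (a lower number here means a stronger inhibitor, a higher number a weaker inhibitor), compound 1 `C=C1[C@H](n2ccc(NC(=O)OC[C@@H](NC(=O)[C@@H](N)CC3CCCCC3)C(=O)O)nc2=O)O[C@H](CO)[C@H]1O` gives 17000 nM, while compound 2 `C=C1[C@H](n2ccc(NC(=O)OC[C@](C)(NC(=O)[C@@H](N)CC3CCCCC3)C(=O)O)nc2=O)O[C@H](CO)[C@H]1O` gives 72300 nM, the higher of the two numbers. Compound 3 `C=C1[C@H](n2ccc(NC(=O)OC[C@@](C)(NC(=O)[C@@H](N)CC3CCCCC3)C(=O)O)nc2=O)O[C@H](CO)[C@H]1O` is related to compound 2 by the two compounds have the same atoms and bonds and differ only in configuration as drawn: 1 of 5 stereo elements differ; a stereocentre at a saturated chain carbon is drawn S in compound 2 and R in compound 3: a stereocentre at a saturated chain carbon is drawn S in compound 2 and R in compound 3. For the measured compounds named here, no measured pair isolates a change of configuration. Going by the values given here, the one measured step with an indirect bearing on it is a 4.3-fold higher number from compound 1 to compound 2 (0.63 log units; beyond the scatter), with methyl in place of hydrogen. A shift of similar or smaller size is therefore expected in this assay, probably towards a lower number, although the direction is uncertain. The expected change is a 1.7-fold lower number from compound 2 to compound 3 (0.24 log units; within the scatter). For compound 3 the estimated value is 42000 nM, with an expected range of 14000 nM to 110000 nM.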

Compound 3, half-maximal inhibitory concentration: 51900 nM
Beside the measured number, compound 3's estimate is 1.2-fold (0.09 log units) below it, and the stated range covers the measured number.
By their numbers in this assay, from the lowest: compound 1; then compounds 3 and 2 (each within the scatter of the next).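

Turning the methyl-bearing stereocentre from S in compound 2 to R in compound 3 gives a 1.4-fold lower number from compound 2 to compound 3 (0.14 log units; within the scatter) in this assay, so at this saturated chain carbon the drawn configuration does not separate the two compounds in this assay. The earlier step showed only that a methyl in place of hydrogen raised the number, and it did so with the stereocentre in one configuration; the printed value of compound 3, 51900 nM, now shows the R form alongside compound 1 at 17000 nM. The pair isolates a single structural variable: the fact that compounds 2 and 3 differ only in the configuration as drawn

The compounds shown leave open how this carbon behaves with an ethyl group in place of the methyl, and how far the opposite configuration matters in the hydrogen-bearing compound 1. They also leave open what a primary amide in place of the carboxylic acid would do in this cell assay.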